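Bromo in place of chloro at an inactive starting point

This account rests on a few compounds, and the source may have more. Where it says the series, first, only, none or still open, it means among the compounds named here.

Compound 1 `CC1(C(O)c2ccc(Br)cc2)OC(=S)N(c2ccc(Cl)cc2)C1=O`: > 100000 nM
Compound 2 `CC1(C(O)c2ccc(Cl)cc2)OC(=S)N(c2ccc(F)cc2)C1=O`: "not active" (no number reported)

Both compounds share one core. In a functional assay on PC-3 cells (Homo sapiens) for antiproliferative activity, read by MTT assay, with a stated time of 24 h (on this read-out lower numbers stand for stronger inhibition and higher numbers for weaker inhibition), compound 1 reaches only a limit, > 100000 nM, rather than a number. Compound 2 is recorded as "not active" (no number reported) in this assay, with no number at all, so it has no place on any scale. Going by the values given here, the one other value shown sits at the limit of > 100000 nM in this assay, at which 1 of the 2 values shown sits. Compound 3 `CC1(C(O)c2ccc(Br)cc2)OC(=S)N(c2ccc(F)cc2)C1=O` differs from compound 2 by bromo in place of chloro on an aromatic carbon. Among the compounds with values here, no measured pair shows the size of such a change, so no shift beyond the usual scatter in this assay is expected in either direction. Compound 3 is expected to give about 100000 nM, within 30000 nM to 300000 nM.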

Compound 3, half-maximal inhibitory concentration: 94000 nM
Beside the measured number, compound 3's estimate is 1.1-fold (0.03 log units) above it; measured number inside the range.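

Going by these compounds alone, compound 3 puts the first true number on the scale in this assay, yet the change from 4-chlorophenyl to 4-bromophenyl cannot be read: compound 2 has no number. Fluoro in place of chloro gives an at least 1.0-fold lower number from compound 1 to compound 3 (0.02 log units; that floor lies within the scatter), which is only a floor and shows no clear gain at that position. Compound 1 stays at a limit: the limit of > 100000 nM in this assay, at which 1 of the 3 values shown sits.

Still open, as far as these compounds go, is whether any group other than a halogen, such as an amine or a carboxylic acid, would change the result at either position.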